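Benzyl on the Ring Oxygen: A Step Beyond the Chain

This account rests on a few compounds, and the source may have more. Where it says the series, first, only, none or still open, it means among the compounds named here.

Compound 1, `NCC(N)CCCNC(=O)CCn1cccc(O)c1=O`: 40.8%
Compound 2, `NCC(N)CCCCNC(=O)CCn1cccc(O)c1=O`: 41.2%

In a physicochemical assay, read by spectrophotometry, with a stated time of 10 min, tested at 0.1 mM, in the presence of a further agent that is not named here (a lower number here means a weaker effect, a higher number a stronger effect of the compound at the concentration tested), compound 2 gives 41.2%, and compound 1 gives 40.8%. Within the data shown here, the one measured step, a number 0.4 percentage points higher from compound 1 to compound 2 (within the scatter), lies within the scatter, so the two compounds sit level with one another on this read-out; neither can be called the more active.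

Compound 3, `NCC(N)CCCCNC(=O)CCn1cccc(OCc2ccccc2)c1=O`, differs from compound 2 in one place: benzyl in place of hydrogen on an oxygen on an aromatic ring. The measured step of a number 0.4 percentage points higher from compound 1 to compound 2 (within the scatter) concerns the chain, not the oxygen on the aromatic ring, so it offers no guide to this change. Among the measured compounds shown here, no measured step bears on a change at this oxygen, and the expectation for compound 3 therefore carries a wide range. The value of compound 3 is estimated at 20%, expected to fall between 2% and 42%. The step of a number 21.2 percentage points lower from compound 2 to compound 3 (beyond the scatter) is thus expected to go downward, though with little certainty.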

Compound 3, a percentage reported as activity, at one concentration (the size of the read-out at that concentration, not a potency): 21.4%
Beside the measured number, compound 3's estimate is 1.4 percentage points below it; low and high end bracket the measured number.
By their numbers in this assay, from the lowest: compound 3; then compounds 1 and 2 (each within the scatter of the next).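

At this oxygen on the aromatic ring, the change from hydroxy to benzyloxy moves the read-out of this assay far more clearly than the chain change did: the result is a number 19.8 percentage points lower from compound 2 to compound 3 (beyond the scatter). The hydrogen on this oxygen therefore matters to the read-out, yet replacing it with benzyl does not remove the effect altogether, since compound 3 still gives 21.4%. Nothing measured here explains why the number falls.

On these data alone, it remains open whether this drop is particular to benzyl or would also appear with a smaller group such as methyl on the same oxygen. As far as these compounds go, it is also open whether benzyl on this oxygen would produce a similar step in compound 1, with its 1,2-diaminoethyl chain.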